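Double-Bond Geometry Change in a Small Growth-Inhibition Series

This account rests on a few compounds, and the source may have more. Where it says the series, first, only, none or still open, it means among the compounds named here.

Measured compounds:
- compound 1 `CC(=O)OC/C(=C\c1ccccc1Br)C(=O)c1ccccc1`, 22000 nM
- compound 2 `CC(=O)OC/C(=C\c1ccccc1F)C(=O)c1ccccc1`, 17000 nM

In a functional assay on HBL-100 cells (Homo sapiens) for inhibition, read by sulforhodamine B assay, with a stated time of 48 h (on this read-out lower numbers stand for stronger inhibition of growth and higher numbers for weaker inhibition of growth), compound 1 gives 22000 nM, the higher of the two numbers, and compound 2 gives 17000 nM. Among the compounds with values here, the one measured step, a 1.3-fold lower number from compound 1 to compound 2 (0.11 log units; within the scatter), swaps one halogen for another on an aromatic carbon and stays within the scatter, so the two compounds cannot be told apart on this read-out.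

Compound 3 `CC(=O)OC/C(=C/c1ccccc1Br)C(=O)c1ccccc1` is not yet measured. Its difference from compound 1 is the two compounds have the same atoms and bonds and differ only in configuration as drawn: 1 of 1 stereo elements differ; a double bond is drawn E in compound 1 and Z in compound 3. Within the data shown here, no measured step touches the geometry of that double bond; the step from compound 1 to compound 2 concerns a halogen swap and says nothing about it. The expectation therefore rests on compound 1 alone, with 22000 nM as the anchor, and no direction of change can be justified from the numbers at hand.

For compound 3 the estimated result is 22000 nM, with an expected range from 6000 nM to 80000 nM, meaning an expected step of no change at the digits printed from compound 1 to compound 3 (within the scatter).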

Compound 3, concentration for 50% growth inhibition: 21000 nM
Estimate against measurement, compound 3: 1.0-fold (0.02 log units) above; low and high end bracket the measured number.
By their numbers in this assay, from the lowest: compounds 2, 3 and 1 (each within the scatter of the next).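

Drawing the double bond Z rather than E gives a 1.0-fold lower number from compound 1 to compound 3 (0.02 log units; within the scatter) in this assay. Within the data shown here, this is the first measured step that touches the geometry of this double bond, and for this bromo pair the two geometries cannot be told apart on this read-out. The comparison is a clean one because nothing else separates the two structures: the fact that compounds 1 and 3 differ only in the configuration as drawn

The result covers only this one pair, so the compounds shown leave open whether the geometry would matter as little with fluoro on the aromatic ring, as in compound 2, whose Z counterpart is not among them. They also leave open whether the same holds once a different group, such as an amine or a carboxylic acid, takes the place of the halogen, since both halogen compounds and both geometries so far sit within the scatter of one another and offer no hint of what would move the number.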